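The source may report more compounds than this note shows. Statements on the series, on what has been measured and on what is new or still open speak of the compounds shown alone.

The measured compounds:

Compound 1, `CCCCCCNc1nc(SCc2ccc(C(F)(F)F)cc2)nc2ccccc12`, gives 13100 nM in a functional assay on MGC-803 cells (Homo sapiens) for cytotoxicity, read by MTT assay, with a stated time of 72 h; on this read-out lower numbers stand for stronger inhibition and higher numbers for weaker inhibition.
Compound 2, `CCCCCCCCNc1nc(SCc2ccc(C(F)(F)F)cc2)nc2ccccc12`, gives 12600 nM in this assay.
Compound 3, `COc1ccccc1Nc1nc(SCc2ccc(C(F)(F)F)cc2)nc2ccccc12`, gives > 50000 nM in this assay; this is a limit of the assay, not a number.

Compounds 1 and 2 share a trifluoromethyl-bearing benzylthio group on the core and differ only in the chain on the ring nitrogen; the step of a 1.0-fold lower number from compound 1 to compound 2 (0.02 log units; within the scatter) is within the scatter. As far as these compounds go, putting a 2-methoxyphenyl on that nitrogen instead gives compound 3, which sits at the limit of the assay: the steps of an at least 3.8-fold higher number from compound 1 to compound 3 (0.58 log units; beyond the scatter) and an at least 3.9-fold higher number from compound 2 to compound 3 (0.59 log units; beyond the scatter) are both beyond the scatter, and their true size is unknown because of the limit of > 50000 nM in this assay, at which 1 of the 3 values shown sits.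

Compound 4, `CCOc1ccccc1Nc1nc(SCc2ccc(C(F)(F)F)cc2)nc2ccccc12`, is not yet measured. It differs from compound 3 by methyl in place of hydrogen on a saturated chain carbon bound to an oxygen on an aromatic ring. For the measured compounds named here, no measured step touches the methoxy oxygen or its carbon; the only comparable homologation, the step from compound 1 to compound 2, was within the scatter. Compound 4 is therefore expected to stand near compound 3, with a number no higher from compound 3 to compound 4 (the limit leaves the size open), and most probably again at the limit of the assay. The estimate for compound 4 is 50000 nM, with a range from 20000 nM to 120000 nM.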

Compound 4, half-maximal inhibitory concentration: > 50000 nM
Compound 4: no number, only a limit; the forecaster's own chance of this, stated with the estimate: 70%; the middle value sits exactly at the limit.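

In this assay, 2-ethoxyphenyl on a nitrogen on an aromatic ring gives the same kind of result as 2-methoxyphenyl did: putting it in place of octyl gives an at least 3.9-fold higher number from compound 2 to compound 4 (0.59 log units; beyond the scatter), and putting it in place of hexyl gives an at least 3.8-fold higher number from compound 1 to compound 4 (0.58 log units; beyond the scatter). So the gap to the two alkyl chains is now seen with two aryl groups rather than one, and adding methyl on the saturated chain carbon bound to an oxygen on an aromatic ring does not bring the number back into the readable range. Compound 3 and compound 4 cannot be ordered, and the step from methoxy to ethoxy cannot be read, because both stand at the limit: the limit of > 50000 nM in this assay, at which 2 of the 4 values shown sit.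

As far as these compounds go, how far past that limit compound 3 and compound 4 truly lie remains open, and so does whether this small change has any effect at all. Also open, from the compounds shown here alone, is whether a hydroxyl, an amine or a longer chain such as butoxy in place of the ethoxy, or a plain phenyl on that nitrogen, would give a measurable number.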